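A few compounds are considered here, and "the series" means these few. Any claim that something is new, unique, unknown or untested is made for them only; others in the source may bear on it.

In a physicochemical assay for metabolic stability, in phosphate buffer, at pH 7.4 (on this read-out lower numbers stand for a shorter-lived compound and higher numbers for a longer-lived compound), compound 1 (`Cc1nc(C)c(C(=O)NCC(=O)Oc2ccc(-c3cc(=O)c4c(O)c(O)c(O)cc4o3)cc2)nc1C`) gives > 72 h as its reading, which is a limit and not a number. Compound 2 (`Cc1nc(C)c(C(=O)N[C@@H](C(=O)Oc2ccc(-c3cc(=O)c4c(O)c(O)c(O)cc4o3)cc2)C(C)C)nc1C`) gives > 72 h as its reading, again a limit. Compound 3 (`Cc1nc(C)c(C(=O)N[C@H](CC(C)C)C(=O)Oc2ccc(-c3cc(=O)c4c(O)c(O)c(O)cc4o3)cc2)nc1C`) gives 69.2 h as a true number. Compound 4 (`Cc1nc(C)c(COC(=O)NCC(=O)Oc2ccc(-c3cc(=O)c4c(O)c(O)c(O)cc4o3)cc2)nc1C`) has (3,5,6-trimethylpyrazin-2-yl)methoxy in place of 3,5,6-trimethylpyrazin-2-yl on a carbonyl carbon. The measured steps bear on this only indirectly, since they alter a saturated chain carbon instead: a step that the two limits leave unreadable from compound 1 to compound 2 and an at least 1.0-fold lower number from compound 1 to compound 3 (0.01 log units; that floor lies within the scatter) and an at least 1.0-fold lower number from compound 2 to compound 3 (0.01 log units; that floor lies within the scatter) are all that is seen. None can be read as beyond the scatter. The expectation rests on compound 3 at 69.2 h and is for no change beyond the scatter in this assay with an expected at least 1.0-fold lower number from compound 1 to compound 4 (0.01 log units; that floor lies within the scatter) as the result. For compound 4 the estimated half-life is 70 h within an expected range of 36 h to 140 h overall.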

Compound 4, half-life: 14.3 h
The estimate for compound 4 lay 4.9-fold (0.69 log units) above the measured number; the whole stated range lies above it.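

In this assay, the change on this carbonyl carbon is the only one shown that reads as beyond the scatter: placing (3,5,6-trimethylpyrazin-2-yl)methoxy in place of 3,5,6-trimethylpyrazin-2-yl gives an at least 5.0-fold lower number from compound 1 to compound 4 (0.70 log units; beyond the scatter). Within the data shown here, the earlier changes on the saturated chain carbon gave no step that can be read as beyond the scatter. This step is only a floor because compound 1 has a limit and not a number: the limit of > 72 h in this assay, at which 2 of the 4 values shown sit.

Going by these compounds, whether an amine in place of the oxygen of the methoxy link would give the same drop remains open. So does whether the drop would persist with isopropyl or isobutyl on the saturated chain carbon.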